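Moving the quinoline nitrogen on the saturated ring carbon

This account rests on a few compounds, and the source may have more. Where it says the series, first, only, none or still open, it means among the compounds named here.

Compound 1 `O=C1OC(c2ccnc3ccccc23)CN1C1CCN(Cc2cc3ccccc3[nH]2)CC1` — 1000 nM
Compound 2 `O=C1OC(c2cccc3ccccc23)CN1C1CCN(Cc2cc3ccccc3[nH]2)CC1` — a limit, < 50200 nM
Compound 3 `O=C1OC(c2cnc3ccccc3c2)CN1C1CCN(Cc2cc3ccccc3[nH]2)CC1` — a limit, < 50200 nM

In an in vitro functional assay on RBL cells for antagonist activity at C-C chemokine receptor type 8 (Homo sapiens), read by FLIPR and calcium flux (on this read-out lower numbers stand for stronger inhibition and higher numbers for weaker inhibition), compound 1 gives 1000 nM. For compound 2 the reading is only a limit of the assay, < 50200 nM. For compound 3 the reading is likewise only a limit of the assay, < 50200 nM. Compound 3 therefore stands on no number of its own, a situation shared with compound 2, as the limit of < 50200 nM in this assay, at which 2 of the 3 values shown sit, records. The three steps among the measured compounds, a step that the limit leaves unreadable from compound 1 to compound 2, a step that the limit leaves unreadable from compound 1 to compound 3 and a step that the two limits leave unreadable from compound 2 to compound 3, cannot be read in size because of the limits.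

Compound 4 `O=C1OC(c2ccc3ccccc3n2)CN1C1CCN(Cc2cc3ccccc3[nH]2)CC1` differs from compound 3 by quinolin-2-yl in place of quinolin-3-yl on a saturated ring carbon. Within the data shown here, no measured step gives a readable size for exchanging one quinolinyl for another on that carbon; the only number in hand is that of compound 1, a third quinolinyl isomer. Compound 4 is therefore expected to lie near compound 1, with an estimate of 2000 nM and a range from 300 nM to 15000 nM. Against the limit of compound 3, the expected step that the limit leaves unreadable from compound 3 to compound 4 is itself not readable and may again end in a limit.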

Compound 4, half-maximal inhibitory concentration: < 50200 nM
Compound 4 was reported as a limit; the forecaster's own chance of this, stated with the estimate: 35%; the middle value does not contradict the limit.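

Compound 4 is also recorded only as a limit of the assay, so no step from compound 1, compound 2 or compound 3 to compound 4 can be read in size: the limit of < 50200 nM in this assay, at which 3 of the 4 values shown sit.

The compounds shown leave open how far compound 2, compound 3 and compound 4 truly stand from compound 1, or from one another, in this assay.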